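The compounds below may be only part of what the source reports. "The series", "measured", "known", "first", "only" and "open" are said of these compounds alone.

Measured compounds:
- Compound 1 `Cc1cccc(/C(N)=N/NC(=S)N2CCCCC2)n1` gives 19.5% in a functional assay on MCF7 cells (Homo sapiens) for cytotoxicity, read by MTT assay, with a stated time of 72 h, tested at 1 uM; on this read-out lower numbers stand for less inhibition of growth and higher numbers for more inhibition of growth at the one concentration tested.
- Compound 2 `N/C(=N\NC(=S)N1CCOCC1)c1ccccn1` gives 14.7% in this assay.
- Compound 3 `Cc1ccnc(/C(N)=N/NC(=S)N2CCCCC2)c1` gives 21.2% in this assay.

Among these three, compound 3 has the highest number in this assay, but its gaps to compound 1 and to compound 2 both lie within the usual scatter of this measurement, so no real ordering can be read from them. All three share the same core, an amidine-like unit linked through a thiourea to a saturated ring.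

Compound 4 `N/C(=N\NC(=S)N1CCCCC1)c1ccccn1` has not yet been measured in this assay. It differs from compound 3 in one place: hydrogen in place of methyl on an aromatic carbon. Among the measured compounds shown here, no pair of measured compounds differs in exactly one place, so no measured step can guide this change directly. Because compound 1 gives 19.5% and compound 3 gives 21.2%, two numbers within scatter of each other although the two compounds carry their methyl in different positions, the step from removing the methyl is expected to be small, in no particular direction, and not beyond the scatter.

Compound 4 is expected to give about 18%, in the range 8% to 30%, which means an expected step of a number 3.2 percentage points lower from compound 3 to compound 4 (within the scatter).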

Compound 4, percent growth inhibition at one concentration: 15.4%
Compound 4: the middle estimate sits 2.6 percentage points above what was measured; measured number inside the range.
By their numbers in this assay, from the lowest: compounds 2, 4, 1 and 3 (each within the scatter of the next).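

Hydrogen in place of the methyl opposite the ring nitrogen gives a number 5.8 percentage points lower from compound 3 to compound 4 (within the scatter) in this assay, and hydrogen in place of the differently placed methyl gives a number 4.1 percentage points lower from compound 1 to compound 4 (within the scatter), so neither exchange separates methyl from hydrogen on this read-out. Piperidin-1-yl in place of morpholin-4-yl on the thiocarbonyl carbon gives a number 0.7 percentage points higher from compound 2 to compound 4 (within the scatter), the first direct look at this ring exchange, and it shows no real difference either. No measurement at hand offers an explanation for these results.

With every step inside the scatter at a single tested concentration, these compounds give no sign that either place affects growth inhibition. Going by these compounds, whether a methoxy group or a carboxylic acid on that aromatic carbon, or a simple dimethylamino group on the thiocarbonyl carbon, would move the number beyond the scatter stays open.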